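Swapping the benzyl ring substituents on a bis(trifluoromethyl)benzenesulfonamide

The source may report more compounds than this note shows. Statements on the series, on what has been measured and on what is new or still open speak of the compounds shown alone.

Measured so far:
Compound 1, `COc1ccc(CNCCCNS(=O)(=O)c2cc(C(F)(F)F)cc(C(F)(F)F)c2)cc1OC`: 13000 nM
Compound 2, `COc1ccccc1CNCCCNS(=O)(=O)c1cc(C(F)(F)F)cc(C(F)(F)F)c1`: 1700 nM

In a functional assay on BXPC-3 cells (Homo sapiens) for inhibition, read by MTT assay, with a stated time of 72 h (on this read-out lower numbers stand for stronger inhibition of growth and higher numbers for weaker inhibition of growth), compound 1 gives the higher of the two numbers, and compound 2 the lower, the gap being a 7.6-fold lower number from compound 1 to compound 2 (0.88 log units; beyond the scatter). Compound 3, `O=S(=O)(NCCCNCc1ccc(Cl)c(Cl)c1)c1cc(C(F)(F)F)cc(C(F)(F)F)c1`, differs from compound 1 by 3,4-dichlorophenyl in place of 3,4-dimethoxyphenyl on a saturated chain carbon bound to an amine nitrogen. For the measured compounds named here, the one measured step bears on the same position and shows that changing the aryl group there can move the number well beyond the scatter, so for compound 3 a modest lowering is expected, a 3.7-fold lower number from compound 1 to compound 3 (0.57 log units; beyond the scatter). Compound 3 is therefore estimated at 3500 nM, with a range of 900 nM to 13000 nM.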

Compound 3, concentration for 50% growth inhibition: 1400 nM
Beside the measured number, compound 3's estimate is 2.5-fold (0.40 log units) above it; low and high end bracket the measured number.
By their numbers in this assay, from the lowest: compounds 3 and 2 (each within the scatter of the next); then compound 1.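

In this assay, 3,4-dichlorobenzyl in place of 3,4-dimethoxybenzyl gives a 9.3-fold lower number from compound 1 to compound 3 (0.97 log units; beyond the scatter) and so matches the size of the earlier step at this position with a second, different aryl group. The step of a 1.2-fold lower number from compound 2 to compound 3 (0.08 log units; within the scatter) leaves these two groups indistinguishable, so of the three groups shown, only 3,4-dimethoxyphenyl stands apart. Nothing available here accounts for this difference. Still open, as far as these compounds go, is how a benzyl ring carrying a single chlorine or an amine would compare, and whether a longer chain would change the picture.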